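Swapping pyridin-3-yl for 4-methylpyrimidin-5-yl on a carbonyl

A few compounds are considered here, and "the series" means these few. Any claim that something is new, unique, unknown or untested is made for them only; others in the source may bear on it.

The three measured compounds differ widely from one another. Compound 1 `CC(=O)Nc1nc(-c2nc(C)no2)cs1` gives 186000 nM in a physicochemical assay for solubility, measured as kinetic solubility, with a stated time of 1 h, at pH 7.4; a lower number here means a less soluble compound, a higher number a more soluble compound. Compound 2 `N#CCC(=O)Nc1cccc(-c2ccc(Cl)c(Cl)c2)n1` gives 1000 nM in this assay. Compound 3 `O=C(NC1=NN(c2ccc(Cl)c(Cl)c2)CC1)c1cccnc1` gives 4000 nM in this assay. Among these three numbers compound 3 stands second highest: its nearest neighbour is compound 2, whose number is lower by an amount beyond the scatter, and its furthest is compound 1, whose number is higher by a much wider margin, also beyond the scatter. Going by the values given here, none of the three pairs differs in only one place, so no single-point step between measured compounds is available.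

Compound 4 `Cc1ncncc1C(=O)NC1=NN(c2ccc(Cl)c(Cl)c2)CC1` has not yet been measured. It differs from compound 3 as follows: 4-methylpyrimidin-5-yl in place of pyridin-3-yl on a carbonyl carbon. Among the compounds with values here, with no measured step to lean on, the expectation for compound 4 rests on the value of compound 3, 4000 nM, as the starting point. Compound 4 is expected to give about 5000 nM in this assay, with a range from 1500 nM to 16000 nM. That estimate means a step of a 1.3-fold higher number from compound 3 to compound 4 (0.10 log units; within the scatter), which is expected to be small, upward if anything, and not clearly beyond the scatter.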

Compound 4, solubility: 12000 nM
For compound 4 the middle estimate is 2.4-fold (0.38 log units) below the measured one, within the range that was stated.
By their numbers in this assay, from the lowest: compound 2; then compound 3; then compound 4; then compound 1.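

In this assay, going by these compounds alone, this is the first comparison between compounds that differ in only one place, and it shows that the group on this carbonyl carbon, whose other neighbour is an amide-type nitrogen, can affect the reading: 4-methylpyrimidin-5-yl in place of pyridin-3-yl gives a 3.0-fold higher number from compound 3 to compound 4 (0.48 log units; beyond the scatter). The step is modest but beyond the scatter, so the change registers as a real rise rather than as repeat-to-repeat variation, and the dichlorophenyl-bearing remainder of the shared core stays the same throughout. The entering group differs in more than one respect, with a ring of 2 hetero atoms instead of 1 and a methyl group in its name, and no measurement separates these features or accounts for the rise.

The compounds shown leave open how much of the step belongs to the methyl group and how much to the ring itself, a question that plain pyrimidin-5-yl would address directly. They also leave open how the number would respond to a quite different group at this carbonyl carbon, such as a morpholine, a carboxylic acid or a longer alkyl chain.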